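Bromo for methyl at the ring-nitrogen-flanked carbon

The compounds below may be only part of what the source reports. "The series", "measured", "known", "first", "only" and "open" are said of these compounds alone.

Three compounds in this series have numbers in an assay on Ltk cells for inhibition of metabotropic glutamate receptor 5 (Homo sapiens), read by fluorescence; a higher number here means a weaker inhibitor, a lower number a stronger inhibitor. Compound 1 `Nc1ncc(Cl)nc1C(=O)Nc1ccccn1` gives 11 nM. Compound 2 `Cc1cccc(NC(=O)c2nc(C)cnc2N)n1` gives 8 nM. Compound 3 `Cc1cccc(NC(=O)c2cccc(C)n2)n1` gives 32 nM, the highest of the three; the gap to compound 1 and the gap to compound 2 both lie beyond the scatter of this assay, so compound 3 stands as the weakest inhibitor among the measured set. Going by the values given here, no single-point step between any two of these measured compounds exists, so no measured step can be read off.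

Compound 4 `Cc1cccc(NC(=O)c2cccc(Br)n2)n1` has not been measured. It differs from compound 3 by bromo in place of methyl on an aromatic carbon of a six-membered aromatic ring with one nitrogen, next to the ring nitrogen, meta to a large group. Among the compounds with values here, the series holds no measured pair that isolates such a swap, and compound 1 carries its halogen on a different ring, so there is no direct precedent to lean on.

Given that, compound 4 is expected to land near compound 3, with the step from compound 3 to compound 4 estimated as a 1.5-fold lower number from compound 3 to compound 4 (0.16 log units; within the scatter), at most a modest shift and possibly none beyond the scatter. In this assay compound 4 is estimated at 22 nM, within a range of 8 nM to 60 nM.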

Compound 4, half-maximal inhibitory concentration: 21 nM
Compound 4: the middle estimate sits 1.0-fold (0.02 log units) above what was measured; the range from low to high includes it.
By their numbers in this assay, from the lowest: compounds 2, 1, 4 and 3 (each within the scatter of the next, the first and the last beyond it).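

In this assay, going by these compounds alone, bromo in place of methyl on an aromatic carbon, next to the ring nitrogen and meta to a large group, gives a 1.5-fold lower number from compound 3 to compound 4 (0.18 log units; within the scatter) as the first measured single-place step. At this position, then, the two groups cannot be told apart in this assay, and a halogen here keeps compound 4 in the same range as compound 3. No measurement at hand bears on why the two groups read alike.

Going by these compounds, whether this carbon accepts other kinds of group remains open, for example methoxy, a carboxylic acid or a longer chain such as propyl. This single pair also leaves open whether the same swap would read alike on another core, such as the core of compound 2.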